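Ring swap on the chain carbon bound to the carbonyl

A few compounds are considered here, and "the series" means these few. Any claim that something is new, unique, unknown or untested is made for them only; others in the source may bear on it.

Compound 3 `CCOc1ncc(-c2nc(C(F)(F)F)sc2N2CCN(C(=O)Cn3ccc4cccnc43)[C@H](C)C2)cn1` holds the lowest number of the three measured compounds in a functional assay on U2OS cells for antagonist activity at C-X-C chemokine receptor type 3 (Homo sapiens), read by beta-arrestin recruitment (on this read-out lower numbers stand for stronger inhibition and higher numbers for weaker inhibition), giving 47 nM. Compound 2 `CCOc1ncc(-c2nc(C(F)(F)F)sc2N2CCN(C(=O)Cn3cnc4ccccc43)[C@H](C)C2)cn1` sits within the scatter of it at 49 nM, while compound 1 `Cc1ncc(-c2nc(C(F)(F)F)sc2N2CCN(C(=O)Cn3cnc4cccnc43)[C@H](C)C2)cn1` gives 168 nM, a number that lies beyond the scatter from compound 3. Compound 4 `CCOc1ncc(-c2nc(C(F)(F)F)sc2N2CCN(C(=O)Cn3ncc4cccnc43)[C@H](C)C2)cn1` differs from compound 3 by a group of 9 heavy atoms (6 carbon, 3 nitrogen; one five-membered aromatic ring with 2 hetero atoms, one six-membered aromatic ring with 1 hetero atom) in place of a group of 9 heavy atoms (7 carbon, 2 nitrogen; one five-membered aromatic ring with 1 hetero atom, one six-membered aromatic ring with 1 hetero atom), on a saturated chain carbon bound to a carbonyl carbon. Among the compounds with values here, the only measured step at this place, a 1.0-fold lower number from compound 2 to compound 3 (0.02 log units; within the scatter), exchanged another pair of bicyclic groups and moved the number only within the scatter. Compound 3 and compound 4 keep the six-membered aromatic ring with 1 hetero atom; only the five-membered ring changes. The step of a 1.2-fold higher number from compound 3 to compound 4 (0.07 log units; within the scatter) is therefore expected to stay within the scatter, in no set direction. For compound 4 the estimate in this assay is 55 nM, with a range from 25 nM to 130 nM.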

Compound 4, half-maximal inhibitory concentration: 55 nM
For compound 4 middle estimate and measured number coincide at the digits printed, within the range that was stated.
By their numbers in this assay, from the lowest: compounds 3, 2 and 4 (each within the scatter of the next); then compound 1.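

Notes on the chain carbon bound to a carbonyl carbon: the step of a 1.2-fold higher number from compound 3 to compound 4 (0.07 log units; within the scatter) and the step of a 1.1-fold higher number from compound 2 to compound 4 (0.05 log units; within the scatter) put a third bicyclic group here within the scatter of the other two. The group with 3 nitrogen atoms and 3 hydrogen-bond acceptors thus gives a number not separable from those of compound 2 and compound 3. No measured property bears on this result.

Open, from the compounds shown here alone, is whether a single ring such as plain phenyl would hold the number at this place. Also open, going by these compounds, is whether a primary amine on the bicyclic group would do so.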